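A few compounds are considered here, and "the series" means these few. Any claim that something is new, unique, unknown or untested is made for them only; others in the source may bear on it.

Measured compounds:
Compound 1 `CC(C)C(=O)Nc1ccc(-c2cnn3c(NCC4CCOCC4)nc(OC4CCCC4)nc23)cc1` — "not determined" (no result reported) in a functional assay on MDA-MB-231 cells (Homo sapiens) for antiproliferative activity; on this read-out higher numbers stand for weaker inhibition of growth and lower numbers for stronger inhibition of growth.
Compound 2 `Cc1cc(-c2cnn3c(NCC4CCOCC4)nc(Nc4ccccc4)nc23)ccc1C(=O)NC1CC1` — 1200 nM.

Within the data shown here, compound 2 therefore holds the only number in this assay; compound 1 offers no comparison. Compound 3 `Cc1cc(-c2cnn3c(NCC4CCOCC4)nc(Nc4cccc(F)c4)nc23)ccc1C(=O)NC1CC1` differs from compound 2 by fluoro in place of hydrogen on an aromatic carbon. Among the measured compounds shown here, no measured pair shows such a step, so nothing here points in either direction, and no change beyond the usual scatter is expected. Compound 3 is expected to give about 1000 nM, with a range from 400 nM to 3000 nM. The expected step, a 1.2-fold lower number from compound 2 to compound 3 (0.08 log units; within the scatter), stays within the scatter of repeated measurements.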

Compound 3, concentration for 50% growth inhibition: 16 nM
Beside the measured number, compound 3's estimate is 63-fold (1.80 log units) above it, outside the stated range (below it).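

In this assay, replacing a single hydrogen with fluoro on the anilino ring gives a 75-fold lower number from compound 2 to compound 3 (1.88 log units; beyond the scatter), meaning stronger inhibition of growth. This carbon of the ring is therefore highly sensitive to a change of just one heavy atom, which compound 2 alone could not reveal. Nothing available here explains the size of this step. On these data alone, whether chloro, methoxy or an amine on the same carbon would act like fluoro remains open, as does the effect of fluoro on the ring's other carbons.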